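This account rests on a few compounds, and the source may have more. Where it says the series, first, only, none or still open, it means among the compounds named here.

Compound 1 `CC(C)n1c(=O)n(C(=O)NCCN2CCN(C)CC2)c2cc(F)ccc21` is the starting point. Among the compounds with values here, in a functional assay for antagonist activity at 5-hydroxytryptamine receptor 4 (Cavia porcellus) (on this read-out higher numbers stand for higher potency (the scale is a negative logarithm) and lower numbers for lower potency), compound 1 gives 6.88, the only value among the three measured compounds that is a number rather than a limit. Compound 2 `CC(C)n1c(=O)n(C(=O)NCCCN2CCN(C)CC2)c2ccccc21` reaches only the limit < 6 in this assay. Compound 3 `CC(C)n1c(=O)n(C(=O)NCCN2CCN(C)CC2)c2cc(F)c(N)cc21` likewise reaches only the limit < 6 in this assay. Within the data shown here, the one step that can be read between measured compounds is a number at least 0.88 log units lower from compound 1 to compound 3 (beyond the scatter), and it ends at the limit of < 6 in this assay, at which 2 of the 3 values shown sit, so only its lower bound is known.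

Compound 4 `COc1ccc2c(c1)n(C(=O)NCCN1CCN(C)CC1)c(=O)n2C(C)C` differs from compound 1 by methoxy in place of fluoro on an aromatic carbon. Among the measured compounds shown here, no measured step covers this exact exchange; the single step from compound 1 to compound 3 changes a different position and shows that one substituent change on this ring can lower potency beyond the scatter. A step in this assay for compound 4 of a size similar to that, in the downward direction, or none beyond the scatter, therefore seems possible, and the estimate takes a middle course. Compound 4 is expected to give 6.5 in this assay, within 5.9 to 7.1. This estimate means an expected step of a number 0.38 log units lower from compound 1 to compound 4 (beyond the scatter).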

Compound 4, negative logarithm of the antagonist equilibrium constant: < 6
Compound 4: a limit, no number; the forecaster's own chance of this, stated with the estimate: 25%; at least 0.50 log units between middle value and limit.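

In this assay, putting methoxy in place of fluoro gives a number at least 0.88 log units lower from compound 1 to compound 4 (beyond the scatter). This shows that the carbon carrying fluoro is itself sensitive to a single exchange, whereas the earlier step, to the amino group of compound 3, concerned a different carbon of the ring and left fluoro in place. The value of compound 4, < 6, is a limit, so the full size of the loss cannot be read: the limit of < 6 in this assay, at which 3 of the 4 values shown sit.

Whether any other group can stand on this carbon and hold the potency of compound 1 stays open, for chloro, methyl and hydroxy are not among the compounds shown. Compound 2 does not settle the case for hydrogen there, since its chain differs as well.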